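The source may hold more compounds than are shown below. What is called first, only, known or untested is meant among the compounds shown, and "the series" means these compounds.

Values in a functional assay on MCF7 cells (Homo sapiens) for inhibition, read by MTT assay, with a stated time of 72 h; on this read-out higher numbers stand for weaker inhibition and lower numbers for stronger inhibition:
- compound 1 `O=C(Nc1ccccc1)C1CCN(C/C=C/c2ccccc2)CC1`: 60200 nM
- compound 2 `O=C(Nc1ccccn1)C1CCN(C/C=C/c2ccccc2)CC1`: 67200 nM
- compound 3 `O=C(NCc1ccccc1)C1CCN(C/C=C/c2ccccc2)CC1`: not yet measured

In this assay, the two measured compounds cannot be told apart: compound 1 gives 60200 nM and compound 2 gives 67200 nM, which places them within the scatter of each other.

The next comparison is the change from compound 2 to compound 3: benzyl in place of pyridin-2-yl on an amide-type nitrogen.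

Among the compounds with values here, only one measured step bears on this change, and it occurs at the same place on the shared core: a 1.1-fold higher number from compound 1 to compound 2 (0.05 log units; within the scatter). Within the data shown here, that step replaces phenyl with pyridin-2-yl, so it is only an indirect guide, and no measured compound in this small set carries benzyl. With this single step as the guide, no shift beyond the scatter is expected in this assay, and no direction is favoured with any confidence.

The estimated step is a 1.2-fold lower number from compound 2 to compound 3 (0.06 log units; within the scatter). As far as these compounds go, the range is kept wide since benzyl is untested here. For compound 3 the estimated value is 58000 nM, with an expected range of 27000 nM to 120000 nM.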

Compound 3, half-maximal inhibitory concentration: > 100000 nM
Compound 3 ended at the assay's limit; the forecaster's own chance of this, stated with the estimate: 15%; at least 1.7-fold (0.23 log units) between middle value and limit.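

In this assay compound 3 gives > 100000 nM, which is a limit of the assay and not a number: the limit of > 100000 nM in this assay, at which 1 of the 3 values shown sits.

Within the data shown here, at the amide-type nitrogen, benzyl is the first group in this small set to reach that limit, whereas pyridin-2-yl in place of phenyl left the two readings within the scatter; the steps to compound 3 are an at least 1.4-fold higher number from compound 2 to compound 3 (0.17 log units; that floor lies within the scatter) and an at least 1.6-fold higher number from compound 1 to compound 3 (0.22 log units; that floor lies within the scatter). Both floors lie within the scatter, so the limit does not by itself set compound 3 apart from compound 1 or compound 2, although it does show that benzyl at this position gives no stronger inhibition than phenyl or pyridin-2-yl.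

As far as these compounds go, how far past the limit compound 3 lies remains open, and with it the true size of both steps. Also open, from the compounds shown here alone, is how a longer chain such as phenethyl, or a benzyl group carrying an amine or a carboxylic acid, would read on this nitrogen in this assay, and whether any group here gives numbers clearly lower than those of compound 1 and compound 2.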